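Removing a second acetyl: stability notes

The compounds below may be only part of what the source reports. "The series", "measured", "known", "first", "only" and "open" are said of these compounds alone.

Going by the values given here, compound 1 `COc1ncnc2c1ncn2[C@@H]1O[C@H](COC(C)=O)[C@@H](OC(C)=O)[C@@H]1OC(C)=O` stands alongside compound 2 in a physicochemical assay for metabolic stability, at pH 7 (a higher number here means that the compound lasts longer, a lower number that the compound disappears faster), the two numbers measured so far lying within the scatter of each other; compound 1 gives a half-life of 365 h. Compound 2 `COc1ncnc2c1ncn2[C@@H]1O[C@H](CO)[C@@H](OC(C)=O)[C@@H]1OC(C)=O` carries hydrogen in place of acetyl on an oxygen on a saturated carbon, and in this assay compound 2 gives 458 h; the step of a 1.3-fold higher number from compound 1 to compound 2 (0.10 log units; within the scatter) is within the scatter. Compound 3 `COc1ncnc2c1ncn2[C@@H]1O[C@H](COC(C)=O)[C@@H](O)[C@@H]1OC(C)=O` is the next case. Its change from compound 1 is hydrogen in place of acetyl on an oxygen on a saturated carbon; read one bond further out, acetoxy becomes hydroxy, on an oxygen on a saturated carbon whose other neighbour is a saturated ring carbon. Among the compounds with values here, the only measured step of the same kind, a 1.3-fold higher number from compound 1 to compound 2 (0.10 log units; within the scatter), stayed within the scatter, so no step beyond the scatter is expected in this assay in either direction. Compound 3 is therefore estimated at 400 h, within 200 h to 800 h, the expected step being a 1.1-fold higher number from compound 1 to compound 3 (0.04 log units; within the scatter).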

Compound 3, half-life: 540 h
Compound 3: middle estimate off by 1.4-fold (0.13 log units), on the low side; the range from low to high includes it.
By their numbers in this assay, from the lowest: compounds 1, 2 and 3 (each within the scatter of the next).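

Hydrogen in place of acetyl on an oxygen on a saturated carbon whose other neighbours are: saturated ring carbon gives a 1.5-fold higher number from compound 1 to compound 3 (0.17 log units; within the scatter). With a 1.3-fold higher number from compound 1 to compound 2 (0.10 log units; within the scatter), there are now two places on the core of compound 1 where this same change stays within the scatter, so neither step in this assay separates the two places. The data offer no explanation for either step.

From the compounds shown here alone, compounds in which more than one acetyl is replaced by hydrogen remain open, so it is unknown whether such changes together would stay within the scatter. Also open, going by these compounds, is whether an amine or a longer chain in place of acetoxy at this place would give a step beyond the scatter in this assay.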